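The source may hold more compounds than are shown below. What is called first, only, known or untested is meant among the compounds shown, and "the series" means these compounds.

Of the compounds shown here, two have been tested in a functional assay on the whole organism (strain Wistar) for inhibition, with Rattus norvegicus as the target, read by paw edema, with stated times of 30 min and 3 h, at a dose of 200 mg/kg by the oral route; on this read-out higher numbers stand for more inhibition at the one dose given (going by the name of the read-out) and lower numbers for less inhibition. Compound 1 `O=C(O)c1cccc(-n2c(-c3ccccc3)cc3c2CCCC3)c1` gives 20%. Compound 2 `COc1ccccc1-c1cc2c(n1-c1ccc(O)c(C(=O)O)c1)CCCC2` gives 50%, the higher of the two numbers, standing well beyond the usual scatter above compound 1. The next compound, compound 3 `O=C(O)c1cc(-n2c(-c3ccc(Cl)cc3)cc3c2CCCC3)ccc1O`, differs from compound 2 in one place: 4-chlorophenyl in place of 2-methoxyphenyl on an aromatic carbon. Among the compounds with values here, no measured pair shows the effect of this change, so its size is open. A modest fall or no change beyond the scatter is expected, giving a number 10 percentage points lower from compound 2 to compound 3 (within the scatter). Compound 3 is therefore estimated at 40%, within the range 20% to 60%.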

Compound 3, a percentage reported as inhibition, in the whole organism at one dose (the size of the read-out at that dose, not a potency): 40%
The estimate for compound 3 equals the measured number at the digits printed; low and high end bracket the measured number.
By their numbers in this assay, from the lowest: compound 1; then compounds 3 and 2 (each within the scatter of the next).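

In this assay, placing 4-chlorophenyl instead of 2-methoxyphenyl on this aromatic carbon next to the ring nitrogen gives a number 10 percentage points lower from compound 2 to compound 3 (within the scatter). This position therefore carries either substituted phenyl ring without a difference that this read-out can separate, although the group that leaves has a hydrogen-bond acceptor and the group that enters has none. Nothing available explains this result. On these data alone, whether an amine or a short alkyl chain at this carbon would keep the number stays open. So does what a carboxylic acid on this phenyl ring would do.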